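A few compounds are considered here, and "the series" means these few. Any claim that something is new, unique, unknown or untested is made for them only; others in the source may bear on it.

In a functional assay on A549 cells (Homo sapiens) for cytotoxicity, read by MTT assay, with a stated time of 48 h (on this read-out higher numbers stand for weaker inhibition and lower numbers for stronger inhibition), compound 1 `NC(=O)CC[C@H](NS(=O)(=O)c1ccc([N+](=O)[O-])cc1)C(=O)O` gives > 500000 nM, which is a limit of the assay and not a number. Compound 2 `CC(C)CNC(=O)CC[C@H](NS(=O)(=O)c1ccc([N+](=O)[O-])cc1)C(=O)O` gives > 500000 nM, again a limit. Within the data shown here, the only measured step is a step that the two limits leave unreadable from compound 1 to compound 2, and the sole evidence is the limit of > 500000 nM in this assay, at which 2 of the 2 values shown sit. Compound 3 `CCCCCNC(=O)CC[C@H](NS(=O)(=O)c1ccc([N+](=O)[O-])cc1)C(=O)O` differs from compound 2 in one side chain: butyl in place of isopropyl on a saturated chain carbon bound to an amide-type nitrogen. In words, this is butyl in place of isopropyl on a saturated chain carbon bound to an amide-type nitrogen, or isobutyl to pentyl when cut one bond further out. The step to compound 2, a step that the two limits leave unreadable from compound 1 to compound 2, gives no size to carry over, so no change beyond the scatter is expected in this assay, in either direction. The expected step is a number no higher from compound 2 to compound 3 (the limit leaves the size open). For compound 3, the estimated value is 500000 nM, with an expected range of 200000 nM to 1000000 nM.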

Compound 3, half-maximal inhibitory concentration: 206000 nM
Beside the measured number, compound 3's estimate is 2.4-fold (0.39 log units) above it, and the stated range covers the measured number.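

At this position on the amide nitrogen, the side chain can move the result off the assay limit: in this assay, butyl in place of isopropyl gives an at least 2.4-fold lower number from compound 2 to compound 3 (0.38 log units; beyond the scatter). Compared with the unsubstituted amide, pentyl in place of hydrogen gives an at least 2.4-fold lower number from compound 1 to compound 3 (0.38 log units; beyond the scatter), so compound 3 is the first compound here to give a number and not a limit. Both steps start from a limit, so each sets only a minimum size and the true size stays open: the limit of > 500000 nM in this assay, at which 2 of the 3 values shown sit.

The pair also leaves unsettled whether the added carbon or the loss of the branch matters more, as isobutyl and pentyl differ in both. From the compounds shown here alone, it remains open whether a longer chain such as octyl, or a chain ending in an amine or a carboxylic acid, would lower the number further.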